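A few compounds are considered here, and "the series" means these few. Any claim that something is new, unique, unknown or untested is made for them only; others in the source may bear on it.

Compound 1 `CC1=C(C(=O)OCC(C)C)C(c2ccco2)NC(=S)N1` and compound 2 `CC1=C(C(=O)OCC(C)C)C(c2ccoc2)NC(=S)N1` share a core that differs from the core of compound 3 `COC(=O)C1=C(C)N(C)C(=O)NC1c1ccco1`; how the two cores differ is not broken down here. In an assay on membranes from CHO cells for displacement of a labelled ligand from adenosine receptor A1 (Homo sapiens), read by scintillation counting, with a stated time of 60 min, tested at 1 uM (on this read-out lower numbers stand for less inhibition and higher numbers for more inhibition at the one concentration tested (going by the name of the read-out)), compound 1 gives 7%, compound 2 gives 12% and compound 3 gives 45%. The step of a number 5 percentage points higher from compound 1 to compound 2 (within the scatter) belongs to the change (furan-3-yl in place of furan-2-yl on a saturated ring carbon). Compound 4 `COC(=O)C1=C(C)N(C)C(=O)NC1c1ccoc1` carries the same kind of change on the core of compound 3, (furan-3-yl in place of furan-2-yl on a saturated ring carbon), where the saturated ring carbon is next to the ring atom that bears a methoxycarbonyl group (4 heavy atoms) rather than a group of 7 heavy atoms, and three ring bonds from the ring atom that bears a methyl group. Because compound 1 to compound 2 shows a number 5 percentage points higher from compound 1 to compound 2 (within the scatter), the step of a number 2 percentage points higher from compound 3 to compound 4 (within the scatter) is the expected one in this assay. Compound 4 is estimated at 47%, between 30% and 62%.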

Compound 4, a percentage reported as inhibition, at one concentration (the size of the read-out at that concentration, not a potency): 15%
Compound 4: middle estimate off by 32 percentage points, on the high side; measured number below the stated range.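

In this assay, the swap of furan-2-yl for furan-3-yl does not carry over from one core to the other, and the result on one core does not predict the result on the other: the same change on two cores in this assay, a number 5 percentage points higher (within the scatter) from compound 1 to compound 2 and a number 30 percentage points lower (beyond the scatter) from compound 3 to compound 4, 35 percentage points apart, beyond the scatter of two such steps. On the core of compound 3 the swap gives a number 30 percentage points lower from compound 3 to compound 4 (beyond the scatter), while on the core of compound 1 it gives a number 5 percentage points higher from compound 1 to compound 2 (within the scatter). Within the data shown here, this shows that the step depends on the core, but not which difference between the cores is responsible, since each core offers only one pair, read at one concentration.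

Still open, as far as these compounds go, is whether a thiophene ring in place of the furan would follow the same split between cores. From the compounds shown here alone, it is also open whether the step on the core of compound 3 survives with a carboxylic acid in place of the methoxycarbonyl group.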